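The source may report more compounds than this note shows. Statements on the series, on what has been measured and on what is new or still open speak of the compounds shown alone.

Going by the values given here, in an ADME assay on BHK cells (Mesocricetus auratus) for cytotoxicity, read by MTT assay, with a stated time of 96 h (a higher number here means that more compound is tolerated, a lower number that less compound is tolerated), compound 2 (`FC(F)(F)c1cccc(NC(=S)Nc2ccccc2)c1`) gives 41000 nM, the higher of the two numbers so far, and compound 1 (`N#Cc1ccc(NC(=S)Nc2cccc(C(F)(F)F)c2)cc1`) gives 9500 nM on the same scale. Compound 3 (`Fc1ccc(NC(=S)Nc2cccc(C(F)(F)F)c2)cc1`) differs from compound 2 by fluoro in place of hydrogen on an aromatic carbon, para to a large group (fluoro in place of hydrogen on an aromatic carbon). Among the compounds with values here, the only measured step that bears on this is the modest 4.3-fold higher number from compound 1 to compound 2 (0.64 log units; beyond the scatter) on replacing cyano with hydrogen, which, read in reverse, links a hydrogen-to-substituent change with a lower number. A smaller move in that same direction is therefore expected (a 2.3-fold lower number from compound 2 to compound 3 (0.36 log units; beyond the scatter)). Compound 3 is estimated at 18000 nM (expected range 7000 nM to 41000 nM).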

Compound 3, half-maximal cytotoxic concentration: 26000 nM
Estimate against measurement, compound 3: 1.4-fold (0.16 log units) below; low and high end bracket the measured number.
By their numbers in this assay, from the lowest: compound 1; then compounds 3 and 2 (each within the scatter of the next).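

In this assay fluoro and hydrogen on the aromatic carbon para to a large group are not told apart (a 1.6-fold lower number from compound 2 to compound 3 (0.20 log units; within the scatter)), a step within the scatter. Fluoro and cyano at that carbon are told apart (a 2.7-fold higher number from compound 1 to compound 3 (0.44 log units; beyond the scatter)), so a substituent there does not by itself set a compound off, and compound 1 alone stands apart from the other two. No measurement at hand bears on why. Open, going by these compounds, is whether an amine, a carboxylic acid or a methoxy group at this carbon would group with compound 1 or with compound 2 and compound 3.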